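A few compounds are considered here, and "the series" means these few. Any claim that something is new, unique, unknown or untested is made for them only; others in the source may bear on it.

Working notes on the series. Among the measured compounds shown here, compound 1 `O=C(CCCCCCc1ccccc1)N1CCCC1` gives 12900 nM in an assay on HEK293 cells for inhibition of N-acylethanolamine-hydrolyzing acid amidase (Rattus norvegicus), read by LC-MS, with a stated time of 30 min (on this read-out higher numbers stand for weaker inhibition and lower numbers for stronger inhibition), and stands second highest of the three numbers so far. Compound 2 `Cc1ccccc1CCCCCCC(=O)N1CCCC1` gives 68400 nM in this assay, and compound 3 `O=C(CCCCCCc1cccc(F)c1)N1CCCC1` gives 7300 nM. The step of a 5.3-fold higher number from compound 1 to compound 2 (0.72 log units; beyond the scatter) is the only one beyond the scatter; the step of a 1.8-fold lower number from compound 1 to compound 3 (0.25 log units; within the scatter) stays within it. Compound 4 `O=C(CCCCCCc1ccc(F)cc1)N1CCCC1` differs from compound 1 by fluoro in place of hydrogen on an aromatic carbon. The step from compound 1 to compound 3 bears most directly on this change and was small, so no step beyond the scatter is expected; a modest downward tendency at most, giving an expected 1.4-fold lower number from compound 1 to compound 4 (0.16 log units; within the scatter). Compound 4 is therefore estimated at 9000 nM, with a range of 4000 nM to 25000 nM.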

Compound 4, half-maximal inhibitory concentration: 8000 nM
Compound 4: the middle estimate sits 1.1-fold (0.05 log units) above what was measured, within the range that was stated.
By their numbers in this assay, from the lowest: compounds 3, 4 and 1 (each within the scatter of the next); then compound 2.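

Fluoro in place of hydrogen para to a large group gives a 1.6-fold lower number from compound 1 to compound 4 (0.21 log units; within the scatter) and so leaves the number within the scatter at this position too. Compounds 3 and 4 also stand within the scatter of each other, so the two fluoro positions cannot be told apart on these numbers. No available evidence bears on the reason for this result.

On these data alone, whether chloro or methoxy at this position would stay within the scatter remains open. Also open, as far as these compounds go, is whether the step of a 5.3-fold higher number from compound 1 to compound 2 (0.72 log units; beyond the scatter) would recur with methyl at this position.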